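Chloro in Place of Trifluoromethyl: an Expected Value

A few compounds are considered here, and "the series" means these few. Any claim that something is new, unique, unknown or untested is made for them only; others in the source may bear on it.

Measured in a functional assay on HeLa cells (Homo sapiens) for antiproliferative activity, read by MTT assay, with a stated time of 72 h (on this read-out lower numbers stand for stronger inhibition and higher numbers for weaker inhibition), so far:
- compound 1, `CCn1cc(C(=O)O)c(=O)c2cc(F)c(N3CCN(C(=N)NS(=O)(=O)c4ccc(C)cc4)CC3)cc21`, gives 32 nM
- compound 2, `N=C(NS(=O)(=O)c1ccc(C(F)(F)F)cc1)N1CCN(c2cc3c(cc2F)c(=O)c(C(=O)O)cn3C2CC2)CC1`, gives 32 nM
- compound 3, `CCn1cc(C(=O)O)c(=O)c2cc(F)c(N3CCN(C(=N)NS(=O)(=O)c4ccc(C(F)(F)F)cc4)CC3)cc21`, gives 32 nM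

Compound 3 stands level with compounds 1 and 2 in this assay. Two single-point steps lead to it: no change at the digits printed from compound 1 to compound 3 (within the scatter), and no change at the digits printed from compound 2 to compound 3 (within the scatter). Neither moved the read-out beyond the scatter.

Compound 4, `CCn1cc(C(=O)O)c(=O)c2cc(F)c(N3CCN(C(=N)NS(=O)(=O)c4ccc(Cl)cc4)CC3)cc21`, is not yet measured. It differs from compound 3 in one place: chloro in place of trifluoromethyl on an aromatic carbon. The step that bears most on this is the one from compound 1 to compound 3, where the same aromatic carbon carried methyl and then trifluoromethyl with no change at the digits shown. A third group at that spot, chloro, is therefore expected to leave the read-out within the same scatter, so the expected step from compound 3 to compound 4 is no change at the digits printed from compound 3 to compound 4 (within the scatter). For compound 4 the estimate in this assay is 32 nM, with a range from 16 nM to 64 nM.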

Compound 4, half-maximal inhibitory concentration: 32 nM
Beside the measured number, compound 4's estimate shows no gap at the digits printed, and the stated range covers the measured number.
By their numbers in this assay, from the lowest: compounds 1, 2, 3 and 4 (each within the scatter of the next).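

With chloro on this aromatic carbon, this assay shows no change at the digits printed from compound 3 to compound 4 (within the scatter) and also no change at the digits printed from compound 1 to compound 4 (within the scatter) for the swap from methyl, so three different groups now sit at this spot with the read-out level. The earlier compounds shown here compared only methyl and trifluoromethyl, whereas this change removes four heavy atoms and puts one heavy atom in their place, and even that leaves the number where it was within these compounds. Nothing available here explains why the read-out stays level at this position.

Still open, from the compounds shown here alone, is whether that level would hold with an amine, a carboxylic acid or a longer chain such as butyl on the same carbon. Also open, going by these compounds, is whether chloro behaves the same way alongside the cyclopropyl on the aromatic nitrogen of compound 2.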